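Second chloro on the aromatic ring: compound 1 to compound 3

The source may hold more compounds than are shown below. What is called first, only, known or untested is meant among the compounds shown, and "the series" means these compounds.

Measured so far:
compound 1, `O=C1/C(=C/c2ccccc2Cl)CCCc2ccccc21`: 18400 nM
compound 2, `COc1ccccc1/C=C1\CCCc2ccccc2C1=O`: 28900 nM

In a functional assay on CCRF-CEM cells (Homo sapiens) for inhibition (a higher number here means a weaker inhibitor, a lower number a stronger inhibitor), compound 1 gives 18400 nM and compound 2 gives 28900 nM; the two numbers lie within the scatter of each other, so compound 1 stands at neither end of anything. For the measured compounds named here, the single measured step, a 1.6-fold higher number from compound 1 to compound 2 (0.20 log units; within the scatter), swaps one group for another and does not add a group. Compound 3, `O=C1/C(=C/c2ccc(Cl)cc2Cl)CCCc2ccccc21`, differs from compound 1 by chloro in place of hydrogen on an aromatic carbon. Going by the values given here, no measured step adds a chloro group, so nothing points to a step beyond the scatter, and compound 3 is expected at a 1.1-fold lower number from compound 1 to compound 3 (0.03 log units; within the scatter). The estimate for compound 3 in this assay is 17000 nM, range 6000 nM to 50000 nM.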

Compound 3, half-maximal inhibitory concentration in the CCRF-CEM assay: 407000 nM
Beside the measured number, compound 3's estimate is 24-fold (1.38 log units) below it, and the stated range ends below it.
By their numbers in the CCRF-CEM assay, from the lowest: compounds 1 and 2 (each within the scatter of the next); then compound 3.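

In the CCRF-CEM assay, chloro in place of hydrogen on this aromatic carbon, meta to a chloro group and para to a large group, gives a 22-fold higher number from compound 1 to compound 3 (1.34 log units; beyond the scatter): a single added atom at this position costs far more than the methoxy for chloro swap did, and compound 3 is clearly the weaker inhibitor. In a physicochemical assay for lipophilicity (on this read-out lower numbers stand for lower lipophilicity and higher numbers for higher lipophilicity), compound 1 gives 5.04 and compound 3 gives 5.65.

One pair cannot separate the two shifts or tie one to the other. From the compounds shown here alone, whether a fluoro, a hydroxyl or an amine at this carbon would also weaken inhibition remains open.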